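Replacing naphthalen-1-yl with 5-bromo-2-fluoropyridin-3-yl

This account rests on a few compounds, and the source may have more. Where it says the series, first, only, none or still open, it means among the compounds named here.

Compound 2 `C=CS(=O)(=O)N1CCN(c2ncnc3sc(-c4cccc5ccccc45)cc23)CC1` gives 28100 nM in a functional assay on MDA-MB-436 cells (Homo sapiens) for antiproliferative activity, read by MTT assay, with a stated time of 48 h; on this read-out lower numbers stand for stronger inhibition and higher numbers for weaker inhibition. That places it within the scatter of compound 3 `C=CS(=O)(=O)N1CCN(c2ncnc3sc(-c4cn(S(=O)(=O)c5ccccc5)c5ccccc45)cc23)CC1`, which gives 38000 nM, while compound 1 `C=CS(=O)(=O)N1CCN(c2ncnc3sc(-c4ccc(C#N)cc4)cc23)CC1` gives 9170 nM, a lower number than either.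

Compound 4 `C=CS(=O)(=O)N1CCN(c2ncnc3sc(-c4cc(Br)cnc4F)cc23)CC1` has not yet been measured. It differs from compound 2 in one place, on an aromatic carbon of a five-membered aromatic ring with 1 sulfur, next to the ring sulfur: 5-bromo-2-fluoropyridin-3-yl in place of naphthalen-1-yl on an aromatic carbon. Within the data shown here, no measured compound carries the entering group.

Among the measured compounds shown here, only one measured step changes the group at this place: a 3.1-fold higher number from compound 1 to compound 2 (0.49 log units; beyond the scatter), with naphthalen-1-yl in place of 4-cyanophenyl. That step is modest, and a single step is thin support. The entering group, like 4-cyanophenyl, is a single six-membered aromatic ring, so a partial return along that step is expected in this assay. This would be a smaller step toward a lower number, possibly not beyond the scatter. The estimated change is a 1.8-fold lower number from compound 2 to compound 4 (0.24 log units; within the scatter). Compound 4 is estimated at 16000 nM, with an expected range of 6000 nM to 40000 nM.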

Compound 4, half-maximal inhibitory concentration: 28400 nM
Compound 4: middle estimate off by 1.8-fold (0.25 log units), on the low side, and the stated range covers the measured number.
By their numbers in this assay, from the lowest: compound 1; then compounds 2, 4 and 3 (each within the scatter of the next).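

At this place, on an aromatic carbon next to the ring sulfur, 5-bromo-2-fluoropyridin-3-yl and naphthalen-1-yl cannot be told apart in this assay with a 1.0-fold higher number from compound 2 to compound 4 (0.00 log units; within the scatter) as the step between them, so a single six-membered aromatic ring does not by itself bring the number back toward that of compound 1. The other new step, a 3.1-fold higher number from compound 1 to compound 4 (0.49 log units; beyond the scatter) and thus beyond the scatter, separates two groups that each hold one six-membered aromatic ring, so among the compounds shown the lower number goes with 4-cyanophenyl and not with the ring count, compound 4 being the case against the count. No measurement shown here offers an account of why these groups match or differ.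

On these data alone, what stays open is whether the lower number of compound 1 belongs to the nitrile or to the phenyl ring that carries it, and a plain phenyl, or a phenyl with a carboxylic acid or an amine where the nitrile stands, would address that. The separate contributions of the bromine, the fluorine and the ring nitrogen in 5-bromo-2-fluoropyridin-3-yl also remain unresolved, as they enter together in a single change.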